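Replacing a Fluorine with a Hydroxyl on the Aniline Ring

This account rests on a few compounds, and the source may have more. Where it says the series, first, only, none or still open, it means among the compounds named here.

Of the compounds shown here, two sharing one core have been measured in an assay on mitochondria from L6 cells (Rattus norvegicus) for activation, with a stated time of 90 min; on this read-out higher numbers stand for an effect only at larger amounts of compound and lower numbers for an effect already at smaller amounts. Compound 1 `Fc1cc(F)c(Nc2nc3nonc3nc2Nc2c(F)cc(F)cc2F)c(F)c1` gives 1100 nM, while compound 2 `Fc1ccc(Nc2nc3nonc3nc2Nc2ccccc2F)c(F)c1` gives 300 nM, the lower of the two numbers and lower by more than the usual scatter. Compound 3 `Oc1ccc(F)c(Nc2nc3nonc3nc2Nc2ccccc2F)c1` is not yet measured; it differs from compound 2 by 2-fluoro-5-hydroxyphenyl in place of 2,4-difluorophenyl on a nitrogen on an aromatic ring. Going by the values given here, no measured pair shows such a change, so no step beyond the scatter is expected in either direction in this assay. Compound 3 is therefore expected to give 400 nM, between 120 nM and 1500 nM, a step of a 1.3-fold higher number from compound 2 to compound 3 (0.12 log units; within the scatter).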

Compound 3, half-maximal effective concentration: 30000 nM
The estimate for compound 3 lay 75-fold (1.88 log units) below the measured number; the measured number lies above the stated range.
By their numbers in this assay, from the lowest: compound 2; then compound 1; then compound 3.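

In this assay, putting 2-fluoro-5-hydroxyphenyl in place of 2,4-difluorophenyl on a nitrogen on an aromatic ring gives a 100-fold higher number from compound 2 to compound 3 (2.00 log units; beyond the scatter), so this position is far less tolerant of change than the first two compounds could reveal. Those two differ in more than one place, so neither isolates a single ring. Nothing measured here explains the size of this step. As far as these compounds go, it remains open whether the rise follows from adding the hydroxyl or from losing a fluorine. A methoxy group or an amine on this ring could help separate those two possibilities.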